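From Butoxy to Octylsulfanyl on a Shared Core

A few compounds are considered here, and "the series" means these few. Any claim that something is new, unique, unknown or untested is made for them only; others in the source may bear on it.

Compound 3 `CCCCO[C@@]1(C(=O)O)C=C[C@@H](NC(C)=O)[C@H]([C@H](O)[C@H](O)CO)O1` stands where every measured member of this small set stands. In an assay on HEK293 cells for inhibition of sialidase-3 (Homo sapiens), read by fluorescence, with a stated time of 1 h (a higher number here means a weaker inhibitor, a lower number a stronger inhibitor), compound 3 gives > 1000000 nM, which is a limit of the assay and not a number. Compound 1 `CO[C@@]1(C(=O)O)C=C[C@@H](NC(C)=O)[C@H]([C@H](O)[C@H](O)CO)O1` gives > 1000000 nM in this assay, again only a limit. Compound 2 `CCCO[C@@]1(C(=O)O)C=C[C@@H](NC(C)=O)[C@H]([C@H](O)[C@H](O)CO)O1` gives > 1000000 nM in this assay, a limit as well. All three values therefore sit at the limit of > 1000000 nM in this assay, at which 3 of the 3 values shown sit, and the steps among them cannot be read in size or direction: a step that the two limits leave unreadable from compound 1 to compound 2, a step that the two limits leave unreadable from compound 1 to compound 3 and a step that the two limits leave unreadable from compound 2 to compound 3.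

Compound 4 `CCCCCCCCS[C@@]1(C(=O)O)C=C[C@@H](NC(C)=O)[C@H]([C@H](O)[C@H](O)CO)O1` differs from compound 3 by octylsulfanyl in place of butoxy on a saturated ring carbon. The three measured steps all concern the chain attached to the oxygen, not an exchange of the oxygen itself, and none of them yields a readable size, so they do not tell in which direction the change to compound 4 should move the number in this assay. With every comparison ending at the same limit, the step of a number no higher from compound 3 to compound 4 (the limit leaves the size open) is expected to remain unreadable rather than show a clear gain or loss. Compound 4 is estimated at 1000000 nM in this assay, within a range from 200000 nM to 5000000 nM, and is expected most likely to be reported as a limit once more.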

Compound 4, half-maximal inhibitory concentration: > 1000000 nM
Compound 4: a limit, no number; the forecaster's own chance of this, stated with the estimate: 80%; the middle value sits exactly at the limit.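

In this assay compound 4 gives > 1000000 nM, a limit of the assay and not a number. The steps to compound 4 from compound 1, compound 2 and compound 3 cannot be read in size or direction, as every value rests at one limit: the limit of > 1000000 nM in this assay, at which 4 of the 4 values shown sit. The compounds shown leave open whether octylsulfanyl in place of butoxy changes inhibition at all.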